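Amide-nitrogen substituent variation on the shared core

The source may report more compounds than this note shows. Statements on the series, on what has been measured and on what is new or still open speak of the compounds shown alone.

Measured so far:
compound 1, `Cc1nc(N)sc1CCCN/C(N)=N/C(=O)N[C@@H](C)c1ccccc1` — in an assay on membranes from Sf9 cells for displacement of a labelled ligand from histamine H2 receptor (Homo sapiens), read by scintillation counting, with a stated time of 60 min (a lower number here means a stronger inhibitor, a higher number a weaker inhibitor), compound 1 gives 51.3 nM
compound 2, `Cc1nc(N)sc1CCCN/C(N)=N/C(=O)NCc1ccco1` — in this assay compound 2 gives 10.5 nM

Within the data shown here, compound 2 holds the lowest of the two numbers; its only neighbour is compound 1, and the one measured step is a 4.9-fold lower number from compound 1 to compound 2 (0.69 log units; beyond the scatter). Compound 3, `CCCCCCNC(=O)/N=C(\N)NCCCc1sc(N)nc1C`, differs from compound 2 by pentyl in place of furan-2-yl on a saturated chain carbon bound to an amide-type nitrogen. Among the measured compounds shown here, no measured step covers this exchange directly. For the measured compounds named here, the single step in hand, a 4.9-fold lower number from compound 1 to compound 2 (0.69 log units; beyond the scatter), concerns another exchange on the same amide-type nitrogen and shows that this position shifts the number by a modest amount. Going by the values given here, with a ring-free chain entering where a ring leaves, and no precedent for such a change, a modest step towards a higher number is expected, though the range must stay wide. Compound 3 is estimated at 22 nM (range 7 nM to 65 nM), an expected step of a 2.1-fold higher number from compound 2 to compound 3 (0.32 log units; beyond the scatter).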

Compound 3, inhibition constant: 28.8 nM
Beside the measured number, compound 3's estimate is 1.3-fold (0.12 log units) below it; the range from low to high includes it.
By their numbers in this assay, from the lowest: compound 2; then compounds 3 and 1 (each within the scatter of the next).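

In this assay, pentyl in place of furan-2-yl on a saturated chain carbon bound to an amide-type nitrogen gives a 2.7-fold higher number from compound 2 to compound 3 (0.44 log units; beyond the scatter) and shows that this position accepts a chain with no ring at a modest cost. Hexyl in place of 1-phenylethyl gives a 1.8-fold lower number from compound 1 to compound 3 (0.25 log units; within the scatter) and shows that the presence of a ring alone does not sort these compounds: compound 1 carries a ring, compound 3 carries none, and only compound 2 stands apart from both. Nothing at hand accounts for these differences.

On these data alone, whether a longer chain such as octyl or a shorter one such as propyl stays with compound 3 remains open. Also open, as far as these compounds go, is whether a (thiophen-2-yl)methyl group, with sulfur in the place of the furan oxygen, stays with compound 2.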